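The compounds below may be only part of what the source reports. "The series", "measured", "known", "first", "only" and "open" are said of these compounds alone.

Of the compounds shown here, three built on one shared core have been tested in an ADME assay on MCF-10A cells (Homo sapiens) for cytotoxicity, read by sulforhodamine B assay, with a stated time of 48 h; on this read-out higher numbers stand for weaker inhibition of growth and lower numbers for stronger inhibition of growth. Compound 1 `CCN(CC)CN1C(=O)/C(=N\c2nc3ccc(C)cc3s2)c2c(Br)cccc21` gives 16100 nM in this assay. Compound 2 `Cc1ccc2nc(/N=C3\C(=O)N(CN4CCCCC4)c4ccccc43)sc2c1` gives 38900 nM. Compound 3 `CCN(CC)CN1C(=O)/C(=N\c2nc3ccc(C)cc3s2)c2c(Cl)cccc21` gives 43900 nM, the highest of the three numbers; compound 2 lies within the scatter of it, and compound 1 stands furthest from it. Among the measured compounds shown here, the only measured step between compounds differing in one place is a 2.7-fold higher number from compound 1 to compound 3 (0.44 log units; beyond the scatter), a halogen exchange on the aromatic ring.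

Compound 4 `Cc1ccc2nc(/N=C3\C(=O)N(CN4CCCCC4)c4cccc(Cl)c43)sc2c1` differs from compound 3 in a single place: piperidin-1-yl in place of diethylamino on a saturated chain carbon bound to an amide-type nitrogen in a ring. For the measured compounds named here, no measured step concerns this exchange. Compound 2 carries the piperidin-1-yl group, but it differs from compound 3 in two places, so only the two values can be compared, and they lie within the scatter of each other. The halogen step from compound 1 to compound 3 says nothing about the amine exchange. Going by the values given here, with no step bearing on the change, the expectation is that the step of a 1.1-fold lower number from compound 3 to compound 4 (0.04 log units; within the scatter) stays within the scatter. Compound 4 is therefore estimated to give about 40000 nM, with a range from 15000 nM to 100000 nM.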

Compound 4, concentration for 50% growth inhibition: 30200 nM
Compound 4: the middle estimate sits 1.3-fold (0.12 log units) above what was measured, within the range that was stated.
By their numbers in this assay, from the lowest: compounds 1, 4, 2 and 3 (each within the scatter of the next, the first and the last beyond it).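

In this assay, among the compounds shown here, the exchange of diethylamino for piperidin-1-yl on a saturated chain carbon bound to an amide-type nitrogen in a ring gives a 1.5-fold lower number from compound 3 to compound 4 (0.16 log units; within the scatter) and so offers the first direct reading of this change: closing the open amine into one six-membered non-aromatic ring does not move the number outside the scatter. For the compounds shown here, with piperidin-1-yl in both compounds, adding chloro to the aromatic ring gives a 1.3-fold lower number from compound 2 to compound 4 (0.11 log units; within the scatter) and is likewise not separated from the scatter, which adds a first reading of a halogen against none to the earlier comparison of two halogens. Nothing measured here offers an explanation for either step.

The chloro and bromo compounds differ by a 2.7-fold higher number from compound 1 to compound 3 (0.44 log units; beyond the scatter) with diethylamino in place, and the compounds shown leave open whether that step would persist with piperidin-1-yl. They also leave open how the read-out would respond if the amine on the saturated chain carbon were morpholin-4-yl or a piperazine, or if a longer chain carried the amine.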